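A few compounds are considered here, and "the series" means these few. Any claim that something is new, unique, unknown or untested is made for them only; others in the source may bear on it.

Compound 2 `CC1CCCN1c1ccc2cc(NC(=O)CCc3ccc(C(F)(F)F)cc3)ccc2n1` needs the most compound of the three measured here: in a functional assay on HEK293 cells for activation of melanin-concentrating hormone receptor 1 (Rattus norvegicus), read by inositol phosphate accumulation (a lower number here means that less compound is needed, a higher number that more compound is needed for the effect), compound 2 gives 270 nM. Compound 1 `O=C(CCc1ccc(C(F)(F)F)cc1)Nc1ccc2nc(N3CCC(NS(=O)(=O)O)C3)ccc2c1` gives 50 nM in this assay, and compound 3 `CNC(=O)NC1CCN(c2ccc3cc(NC(=O)CCc4ccc(C(F)(F)F)cc4)ccc3n2)C1` gives 30 nM. Both neighbours carry, in place of the 2-methylpyrrolidin-1-yl of compound 2, a pyrrolidine bearing a group with hydrogen-bond donors; the two steps are a 5.4-fold higher number from compound 1 to compound 2 (0.73 log units; beyond the scatter) and a 9.0-fold lower number from compound 2 to compound 3 (0.95 log units; beyond the scatter). Compound 4 `CCN(CC)c1ccc2cc(NC(=O)CCc3ccc(C(F)(F)F)cc3)ccc2n1` changes the same spot in another way: diethylamino in place of 2-methylpyrrolidin-1-yl on an aromatic carbon. For the measured compounds named here, no measured step opens the ring or removes it, and the entering group, like the leaving one, has no hydrogen-bond donor, so the two measured steps give little guidance beyond showing that this spot matters. The expectation for compound 4 is therefore a number close to that of compound 2, with wide uncertainty, a step of a 1.5-fold higher number from compound 2 to compound 4 (0.17 log units; within the scatter). Compound 4 is estimated at 400 nM, between 150 nM and 1100 nM.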

Compound 4, half-maximal effective concentration: 830 nM
Beside the measured number, compound 4's estimate is 2.1-fold (0.32 log units) below it; low and high end bracket the measured number.
By their numbers in this assay, from the lowest: compounds 3 and 1 (each within the scatter of the next); then compound 2; then compound 4.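

Opening the ring is not a neutral change at this spot next to the ring nitrogen: in this assay there is a 3.1-fold higher number from compound 2 to compound 4 (0.49 log units; beyond the scatter), although the leaving and entering groups both have no hydrogen-bond donor. For the compounds shown here, the gaps to the two pyrrolidines with a substituted amino group are wider still, with a 28-fold higher number from compound 3 to compound 4 (1.44 log units; beyond the scatter) and a 17-fold higher number from compound 1 to compound 4 (1.22 log units; beyond the scatter), so this spot now spans a larger range of numbers than the earlier compounds showed. Nothing at hand explains why the open chain needs more compound than the ring.

The step from compound 2 to compound 4 both removes the ring and changes the carbon count, so those two changes cannot be told apart. A dimethylamino group or a piperidine ring at this spot could help separate them.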